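The compounds below may be only part of what the source reports. "The series", "measured", "known", "first", "only" and "open" are said of these compounds alone.

Working notes on the series.

The shared core is seen in compound 1 `O=C(Nc1cc(C(F)(F)F)ccc1N1CCCC1)c1ccncc1`, whose cytotoxicity was measured in a functional assay on NALM-6 cells (Homo sapiens) for cytotoxicity, read by MTT assay, with a stated time of 48 h; a higher number here means a weaker inhibitor, a lower number a stronger inhibitor. There compound 1 is recorded as "not active" (no number reported), so no single number stands for it and its place on the scale cannot be fixed. The only numerical point in the set comes from compound 2 `O=C(Nc1cc(C(F)(F)F)ccc1Nc1ccc(Br)cc1)c1ccncc1`: in this assay compound 2 gives 51900 nM, a weak inhibition. For the measured compounds named here, no step between two measured compounds that differ in one place exists here, so compound 1 and compound 2 can only be set side by side as two weak results.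

Compound 3 `O=C(Nc1cc(C(F)(F)F)ccc1N1CCCC1)c1ccccc1` has not been measured. It differs from compound 1 in one place (phenyl in place of pyridin-4-yl on a carbonyl carbon).

With compound 1 reported as "not active" (no number reported), there is no number from which to count a step in this assay, so the size of the change from compound 1 to compound 3 cannot be expected in either direction beyond the scatter. The expectation rests on compound 2 giving 51900 nM as the sole anchor of the series. Compound 3 is expected to give about 60000 nM in this assay, estimated within 20000 nM to 200000 nM, with a real chance that again only an inactive call is reported.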

Compound 3, half-maximal inhibitory concentration: "not active" (no number reported)
Compound 3 has no reported number here; the estimate stays without a comparison.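

In this assay, for the compounds shown here, compound 3 joins compound 1 as a result without a number, so no step between compound 1 and compound 3 can be read. No measurement shown offers an explanation for either result. The compounds shown leave open whether exchanging pyridin-4-yl for phenyl on the carbonyl carbon changes cytotoxicity at all.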